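This account rests on a few compounds, and the source may have more. Where it says the series, first, only, none or still open, it means among the compounds named here.

Measured in a physicochemical assay for solubility, in phosphate buffer, at pH 6.5; on this read-out higher numbers stand for higher solubility and lower numbers for lower solubility:
- Compound 1 `CCOc1cc(CN2CCC(NC(=O)c3ccc(NC)nc3)CC2)cc(OCC)c1F`: 330 ug/mL
- Compound 2 `CCOc1cc(CN2CCC(NC(=O)c3ccc(NC)nc3)CC2)cc(OCC)c1-c1ccc(F)cc1`: 153 ug/mL
- Compound 3 `CCOc1cc(CN2CCC(NC(=O)c3cncc(C)c3)CC2)ccc1C`: > 433 ug/mL, a limit of the assay

For the measured compounds named here, of the two exact numbers, compound 1 holds the higher, and the only measured step is a 2.2-fold lower number from compound 1 to compound 2 (0.33 log units; beyond the scatter), a modest one that lies beyond the scatter. The next compound, compound 4 `CCOc1cc(CN2CCC(NC(=O)c3cncc(C)c3)CC2)cc(OCC)c1F`, keeps the rest of compound 1 and changes the group on the carbonyl carbon: 5-methylpyridin-3-yl in place of 6-(methylamino)pyridin-3-yl on a carbonyl carbon. The measured step does not make this exchange, since it puts 4-fluorophenyl in place of fluoro on an aromatic carbon, so it bears on the new change only indirectly. The closer hint comes from compound 3, which carries the same 5-methylpyridin-3-yl on its carbonyl carbon but differs elsewhere in the structure. Compound 3 sits at the limit of > 433 ug/mL in this assay, at which 1 of the 3 values shown sits, and that value is a limit, not a number. A small upward move or none beyond the scatter is therefore expected, and the estimated step is a 1.2-fold higher number from compound 1 to compound 4 (0.08 log units; within the scatter). For compound 4 the expected value is 400 ug/mL, with an estimated range of 200 ug/mL to 800 ug/mL.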

Compound 4, solubility: 443 ug/mL
Estimate against measurement, compound 4: 1.1-fold (0.04 log units) below; the range from low to high includes it.
By their numbers in this assay, from the lowest: compound 2; then compounds 1 and 4 (each within the scatter of the next).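

In this assay, for the compounds shown here, the exchange on the carbonyl carbon gives a 1.3-fold higher number from compound 1 to compound 4 (0.13 log units; within the scatter), the first reading at this position of the core of compound 1. Going by these compounds alone, the only earlier step was at the aromatic carbon, a 2.2-fold lower number from compound 1 to compound 2 (0.33 log units; beyond the scatter), and it lay beyond the scatter, whereas 5-methylpyridin-3-yl in place of 6-(methylamino)pyridin-3-yl, with one hydrogen-bond donor fewer by the counts for these groups, does not. Compound 3 carries the same 5-methylpyridin-3-yl but differs elsewhere, and its value remains a limit and not a number: the limit of > 433 ug/mL in this assay, at which 1 of the 4 values shown sits.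

The compounds shown leave open whether the 4-fluorophenyl exchange would give a similar step on compound 4. They also leave open how this assay would respond to a primary amine or a carboxylic acid on the pyridine ring at this position.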